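This account rests on a few compounds, and the source may have more. Where it says the series, first, only, none or still open, it means among the compounds named here.

Measured compounds in a functional assay on PC-3 cells (Homo sapiens) for cytotoxicity, read by MTT assay, with a stated time of 72 h; on this read-out lower numbers stand for stronger inhibition and higher numbers for weaker inhibition:
- compound 1 `COc1ccc(Cn2nc(-c3ccccc3)c3cc(C(=N)Nc4ccccc4)nc(NC4CCCCC4)c32)cc1`: 1100 nM
- compound 2 `N=C(Nc1ccccc1)c1cc2c(-c3ccccc3)n[nH]c2c(NC2CCCCC2)n1`: 1730 nM
- compound 3 `COc1ccc(Cn2nc(-c3ccccc3)c3cc(C(=N)Nc4ccc(N5CCN(C)CC5)cc4)nc(NC4CCCCC4)c32)cc1`: 3540 nM

Compound 1 gives the lowest number of the three in this assay, though compound 2 is within the scatter of it: a 1.6-fold higher number from compound 1 to compound 2 (0.20 log units; within the scatter). Compound 3 stands furthest off: a 3.2-fold higher number from compound 1 to compound 3 (0.51 log units; beyond the scatter).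

Compound 4 `COc1ccc(Cn2nc(-c3ccccc3)c3cc(C(=N)Nc4ccccc4)ncc32)cc1` is not yet measured. It differs from compound 1 in one place: hydrogen in place of cyclohexylamino on an aromatic carbon. Neither measured step bears directly on this change. The step from compound 1 to compound 2 removes a group on the aromatic nitrogen and stays within the scatter; the step from compound 1 to compound 3 adds a group on an aromatic carbon and raises the number modestly. Nothing shown tests what happens when the cyclohexylamino group itself is removed, so no measured step anchors the expectation.

Given that the group leaving is the larger of the changes seen so far, compound 4 is expected to give a higher number in this assay: a 3.6-fold higher number from compound 1 to compound 4 (0.56 log units; beyond the scatter). The estimate for compound 4 is 4000 nM, with a range from 1200 nM to 15000 nM.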

Compound 4, half-maximal inhibitory concentration: 6300 nM
Compound 4: middle estimate off by 1.6-fold (0.20 log units), on the low side; the measured number falls inside the stated range.
By their numbers in this assay, from the lowest: compounds 1 and 2 (each within the scatter of the next); then compounds 3 and 4 (each within the scatter of the next).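

In this assay, among the compounds shown here, the cyclohexylamino group on this aromatic carbon, next to the ring nitrogen, is the first substituent of compound 1 whose removal has been read directly, and hydrogen in its place moves the number beyond the scatter (a 5.7-fold higher number from compound 1 to compound 4 (0.76 log units; beyond the scatter)). The position therefore differs from the aromatic nitrogen, where hydrogen in place of 4-methoxybenzyl stays within the scatter (a 1.6-fold higher number from compound 1 to compound 2 (0.20 log units; within the scatter)). Nothing available explains why the number rises at this position.

Going by these compounds, whether the step follows the carbocycle or the amine nitrogen remains open; an unsubstituted amino group, a methylamino group or a phenylamino group on this carbon would separate the two. On these data alone, whether the step holds with hydrogen on the aromatic nitrogen, as in compound 2, also remains open.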